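Six-substituent swap on the thiophenyl nucleoside core

The compounds below may be only part of what the source reports. "The series", "measured", "known", "first", "only" and "open" are said of these compounds alone.

Measured so far:
compound 1 `COc1ncnc2c1c(-c1cccs1)cn2[C@@H]1O[C@H](CO)[C@@H](O)[C@H]1O` – 12100 nM
compound 2 `COc1nc(N)nc2c1c(-c1cccs1)cn2[C@@H]1O[C@H](CO)[C@@H](O)[C@H]1O` – > 20000 nM
compound 3 `C#Cc1cn([C@@H]2O[C@H](CO)[C@@H](O)[C@H]2O)c2ncnc(OC)c12` – 3490 nM

In a functional assay on CEM-DNR-bulk cells (Homo sapiens), read by MTT assay, with a stated time of 72 h (on this read-out lower numbers stand for stronger inhibition and higher numbers for weaker inhibition), compound 1 gives 12100 nM. For compound 2 the value is a limit of the assay, (the limit of > 20000 nM in this assay, at which 1 of the 3 values shown sits). Compound 1 has the highest of the two numbers; compound 3 gives 3490 nM, a step of a 3.5-fold lower number from compound 1 to compound 3 (0.54 log units; beyond the scatter). Compound 4 `CN(C)c1ncnc2c1c(-c1cccs1)cn2[C@@H]1O[C@H](CO)[C@@H](O)[C@H]1O` differs from compound 1 by dimethylamino in place of methoxy on an aromatic carbon. Neither measured step touches the methoxy: an at least 1.6-fold higher number from compound 1 to compound 2 (0.21 log units; that floor lies within the scatter) changes another position of the same six-membered ring and sits within the scatter, and a 3.5-fold lower number from compound 1 to compound 3 (0.54 log units; beyond the scatter) changes the thiophen-2-yl. Going by the values given here, no step therefore predicts a direction, and no step beyond the scatter is expected in this assay. Compound 4 is estimated at 15000 nM, between 4000 nM and 40000 nM, meaning an expected step of a 1.2-fold higher number from compound 1 to compound 4 (0.09 log units; within the scatter).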

Compound 4, half-maximal inhibitory concentration: > 20000 nM
Compound 4 was reported as a limit; the forecaster's own chance of this, stated with the estimate: 30%; at least 1.3-fold (0.12 log units) between middle value and limit.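

Compound 4 is the first change at the methoxy itself, and its reading is a limit of the assay, not a number: the limit of > 20000 nM in this assay, at which 2 of the 4 values shown sit.

The swap reads as an at least 1.6-fold higher number from compound 1 to compound 4 (0.21 log units; that floor lies within the scatter), so dimethylamino on this aromatic carbon shows no gain over methoxy, while the floor alone establishes no loss.

Still open, as far as these compounds go, are how far past the limit compound 4 lies and how an unsubstituted amine or an ethoxy would read at this place. Also open, from the compounds shown here alone, is whether dimethylamino behaves the same alongside the ethynyl of compound 3.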